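A Longer Alkyl Chain on the Shared Core: Compound 4

The source may hold more compounds than are shown below. What is called first, only, known or untested is meant among the compounds shown, and "the series" means these compounds.

Measured compounds:
Compound 1, `CCCCN1NN=C(NC(=O)Nc2c(C(C)C)cccc2C(C)C)N1`: 92 nM
Compound 2, `CCCCCCN1NN=C(NC(=O)Nc2c(C(C)C)cccc2C(C)C)N1`: 73 nM
Compound 3, `CCCCCCCCCN1NN=C(NC(=O)Nc2c(C(C)C)cccc2C(C)C)N1`: 31 nM

All three compounds share one core and differ only in the length of the alkyl chain attached to the ring nitrogen. In an assay on microsomes from intestine for inhibition of acyl-CoA:cholesterol acyltransferase (Oryctolagus cuniculus) (a lower number here means a stronger inhibitor, a higher number a weaker inhibitor), compound 3 stands lowest of the three numbers; its nearest neighbour is compound 2 at a number higher by a 2.4-fold lower number from compound 2 to compound 3 (0.37 log units; beyond the scatter), and compound 1 lies furthest away at a 3.0-fold lower number from compound 1 to compound 3 (0.47 log units; beyond the scatter).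

Compound 4, `CCCCCCCCCCCN1NN=C(NC(=O)Nc2c(C(C)C)cccc2C(C)C)N1`, carries the chain two carbons further: ethyl in place of hydrogen on a saturated chain carbon, nine bonds along the chain from an amine nitrogen in a ring.

The measured steps all extend this same chain. The step of a 1.3-fold lower number from compound 1 to compound 2 (0.10 log units; within the scatter) was too small to count, while a 2.4-fold lower number from compound 2 to compound 3 (0.37 log units; beyond the scatter) and a 3.0-fold lower number from compound 1 to compound 3 (0.47 log units; beyond the scatter) were modest decreases. Going from compound 3 to compound 4 is a smaller extension than either of the earlier ones, so only a small further drop, or none beyond the scatter, is expected in this assay.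

Compound 4 is therefore estimated at 20 nM in this assay, within the range 8 nM to 50 nM. This estimate corresponds to an expected step of a 1.6-fold lower number from compound 3 to compound 4 (0.19 log units; within the scatter).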

Compound 4, half-maximal inhibitory concentration: 9 nM
Beside the measured number, compound 4's estimate is 2.2-fold (0.35 log units) above it; low and high end bracket the measured number.
By their numbers in this assay, from the lowest: compound 4; then compound 3; then compounds 2 and 1 (each within the scatter of the next).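

In this assay, the ethyl placed nine bonds along the chain from an amine nitrogen in a ring gives a 3.4-fold lower number from compound 3 to compound 4 (0.54 log units; beyond the scatter), so the gain from lengthening the chain has not run out at compound 3, and the longest chain now stands well clear of the shorter ones, with an 8.1-fold lower number from compound 2 to compound 4 (0.91 log units; beyond the scatter) and a 10-fold lower number from compound 1 to compound 4 (1.01 log units; beyond the scatter). What the earlier compounds could not show is that the same addition is worth more on a longer chain than on a shorter one, so each added carbon cannot be given one fixed value; the ethyl addition shows this: the same change on two cores in this assay, a 1.3-fold lower number (0.10 log units; within the scatter) from compound 1 to compound 2 and a 3.4-fold lower number (0.54 log units; beyond the scatter) from compound 3 to compound 4, 2.7-fold (0.44 log units) apart, beyond the scatter of two such steps The pentyl addition, made at a different point along the chain, shows the same: the same change on two cores in this assay, a 3.0-fold lower number (0.47 log units; beyond the scatter) from compound 1 to compound 3 and an 8.1-fold lower number (0.91 log units; beyond the scatter) from compound 2 to compound 4, 2.7-fold (0.44 log units) apart, beyond the scatter of two such steps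

The compounds shown end with compound 4, so it remains open whether a still longer chain would lower the number further or whether the trend would level off or reverse. Also open, on these data alone, is how this position would respond to a branched chain, or to a chain ending in an amine or a carboxylic acid.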